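Branching the ester and amide side chains at the A3 receptor

A few compounds are considered here, and "the series" means these few. Any claim that something is new, unique, unknown or untested is made for them only; others in the source may bear on it.

Compound 1 `CCCOC(=O)C1=C(C)N(C)C(=O)NC1c1ccco1` and compound 2 `CC1=C(C(=O)OCC(C)C)C(c2ccco2)NC(=O)N1C` share one core, while compound 3 `CCNC(=O)C1=C(C)NC(=O)NC1c1ccsc1` and compound 4 `CC1=C(C(=O)NC(C)C)C(c2ccsc2)NC(=O)N1` share another; the difference between the two cores is not broken down here. In an assay on membranes from HeLa cells for displacement of a labelled ligand from adenosine receptor A3 (Homo sapiens), read by scintillation counting, with a stated time of 180 min, tested at 1 uM (on this read-out lower numbers stand for less inhibition and higher numbers for more inhibition at the one concentration tested (going by the name of the read-out)), compound 1 gives 8%, and compound 2 gives 23%. The step between them, (methyl in place of hydrogen on a saturated chain carbon bound to two saturated chain carbons), reads as a number 15 percentage points higher from compound 1 to compound 2 (beyond the scatter). In this assay compound 3 gives 1%, a number near that of compound 1 and well apart from that of compound 2. Compound 4 differs from compound 3 by methyl in place of hydrogen on a saturated chain carbon bound to an amide-type nitrogen and a saturated chain carbon. This is the same kind of change as that from compound 1 to compound 2, yet the surroundings differ: in one case the place is on a saturated chain carbon bound to two saturated chain carbons, in the other on a saturated chain carbon bound to an amide-type nitrogen and a saturated chain carbon. Among the compounds with values here, with only one measured example of the change, on a different core, the expected step is a number 7 percentage points higher from compound 3 to compound 4 (within the scatter), a smaller gain than the ester pair showed. Compound 4 is therefore estimated at 8%, expected to fall between -4% and 22%.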

Compound 4, a percentage reported as inhibition, at one concentration (the size of the read-out at that concentration, not a potency): 1%
Compound 4: the middle estimate sits 7 percentage points above what was measured; measured number inside the range.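

In this assay, the methyl that turns ethylcarbamoyl into isopropylcarbamoyl reads as no change at the digits printed from compound 3 to compound 4 (within the scatter), so the gain seen with the ester side chain did not carry over to the amide side chain: the same change on two cores in this assay, a number 15 percentage points higher (beyond the scatter) from compound 1 to compound 2 and no change at the digits printed (within the scatter) from compound 3 to compound 4, 15 percentage points apart, beyond the scatter of two such steps The step measured on one core therefore cannot simply be transferred to the other in this series. This does not show why the two steps differ, since the pairs differ both in their cores and in the surroundings of the changed carbon, and a single pair on each side cannot separate these influences.

The compounds shown leave open whether the ester side chain of compound 2 would keep its higher number on the core of compound 3, and whether an amide side chain would behave on the core of compound 1 as it does here. They also leave open how a longer chain or a carboxylic acid at the same place would read on either core.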